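A larger group on the ring nitrogen of compound 1

A few compounds are considered here, and "the series" means these few. Any claim that something is new, unique, unknown or untested is made for them only; others in the source may bear on it.

Measured compounds:
compound 1, `CCN1C(=O)S/C(=C\c2ccc(N)cc2)C1=O`, 108000 nM
compound 2, `C=C(Br)C(=O)Nc1cccc(/C=C2\SC(=O)N(Cc3ccc(C(F)(F)F)cc3)C2=O)c1`, 820 nM

The read-out is a functional assay on HeLa cells (Homo sapiens) for cytotoxicity, read by cell counting, with a stated time of 4 days; a higher number here means a weaker inhibitor, a lower number a stronger inhibitor. Compound 1 has the highest number of the two measured compounds, so it is the weaker of them; in this assay compound 1 gives 108000 nM, while compound 2 gives 820 nM, a much lower number, and the gap lies beyond the scatter. Among the measured compounds shown here, compound 2 differs from compound 1 in several places at once, so no single step between them can be drawn.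

Compound 3, `Nc1ccc(/C=C2\SC(=O)N(Cc3cccc(F)c3)C2=O)cc1`, keeps the core of compound 1 and changes one place: 3-fluorophenyl in place of methyl on a saturated chain carbon bound to an amide-type nitrogen in a ring. For the measured compounds named here, no measured pair shows this change alone. Since compound 2 carries a larger group at the same position and gives a far lower number, compound 3 is expected to move toward lower numbers, with a step of a 5.4-fold lower number from compound 1 to compound 3 (0.73 log units; beyond the scatter) that is estimated to lie beyond the scatter. The expected value for compound 3 is 20000 nM, estimated to fall between 4000 nM and 90000 nM.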

Compound 3, half-maximal inhibitory concentration: 250000 nM
Estimate against measurement, compound 3: 13-fold (1.10 log units) below, outside the stated range (above it).
By their numbers in this assay, from the lowest: compound 2; then compound 1; then compound 3.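

Putting 3-fluorophenyl in place of methyl at this position gives a 2.3-fold higher number from compound 1 to compound 3 (0.36 log units; beyond the scatter) in this assay, a modest move toward a weaker inhibitor. This shows that a larger group here does not by itself lower the number, and the far lower number of compound 2, which differs from compound 1 in several places, cannot be credited to this position alone. Nothing measured here explains the direction of this step.

From the compounds shown here alone, it remains open whether an unsubstituted phenyl, an amine, a carboxylic acid or a longer chain at this position would move the number differently. Among the compounds shown here, it also remains open which of the several differences in compound 2 goes with its lower number, as no single step connects it to compound 1 or compound 3.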